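The compounds below may be only part of what the source reports. "The series", "measured", "known", "first", "only" and "open" are said of these compounds alone.

Measured compounds:
compound 1, `O=C(O)CCc1ccc(C#Cc2ccnc(Oc3ccccc3)c2)cc1`, 479 nM
compound 2, `O=C(O)CCc1ccc(C#Cc2ccncc2)cc1`, 4070 nM

Both compounds were tested in an in vitro functional assay on 1321-N1 cells for agonist activity at Free fatty acid receptor 1 (Homo sapiens), read by fluorescence, spectrophotometry and calcium flux; on this read-out higher numbers stand for an effect only at larger amounts of compound and lower numbers for an effect already at smaller amounts. Compound 2 stands at the highest of the two numbers; its nearest neighbour is compound 1, which differs by an 8.5-fold higher number from compound 1 to compound 2 (0.93 log units; beyond the scatter), a step that exchanges hydrogen for phenoxy on an aromatic carbon and leaves the rest of the shared core untouched.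

Compound 3, `O=C(O)CCc1ccc(C#Cc2cccs2)cc1`, has not yet been measured. It departs from compound 2 as follows: thiophen-2-yl in place of pyridin-4-yl on a triple-bonded carbon. Going by the values given here, no measured pair shows such an exchange of one heteroaromatic ring for another at the triple-bonded carbon; the only recorded step, from compound 1 to compound 2, concerns a substituent on the ring and says nothing about replacing the ring itself. There is therefore no measured footing for a directional expectation in this assay, and the change is expected to give a step of a 1.4-fold lower number from compound 2 to compound 3 (0.13 log units; within the scatter), which may fall either side of the number for compound 2.

The estimate for compound 3 in this assay is accordingly 3000 nM, with a range from 700 nM to 12000 nM.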

Compound 3, half-maximal effective concentration: 251 nM
Estimate against measurement, compound 3: 12-fold (1.08 log units) above; measured number outside the range, below it.
By their numbers in this assay, from the lowest: compounds 3 and 1 (each within the scatter of the next); then compound 2.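

In this assay, the exchange on the triple-bonded carbon gives a 16-fold lower number from compound 2 to compound 3 (1.21 log units; beyond the scatter), so the number responds to the identity of the ring held there and not only to a substituent carried on that ring, which was all that the earlier step had touched. The exchange alters two things at once: a six-membered aromatic ring with nitrogen as its hetero atom leaves, and a five-membered aromatic ring with sulfur as its hetero atom enters, while the counts of hydrogen-bond donors and acceptors stay the same, so this single step cannot separate ring size from the identity of the hetero atom. No measurement is available here that explains the size of this step.

From the compounds shown here alone, whether phenyl, furan-2-yl or thiophen-3-yl on the same triple-bonded carbon would give a number closer to that of compound 3 or that of compound 2 remains open. Also open, going by these compounds, is what phenoxy would do on the thiophen-2-yl ring, and whether the gain seen with compound 3 would survive an amide in place of the carboxylic acid.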